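Methoxy for Fluoro on a Core with Wide-Ranging Results

The source may report more compounds than this note shows. Statements on the series, on what has been measured and on what is new or still open speak of the compounds shown alone.

In a functional assay on HL-60 cells (Homo sapiens) for antiproliferative activity (a lower number here means a stronger inhibitor, a higher number a weaker inhibitor), compound 1 (`COc1ccc(-c2snnc2-c2cc(OC)c(OC)c(OC)c2)cc1O`) gives 1.5 nM as its result, which is very strong. Compound 2 (`COc1cc(-c2nnsc2-c2ccc([N+](=O)[O-])cc2)cc(OC)c1OC`) reads > 1000 nM in the same test, and this is a limit of the assay and not a number. Compound 3 (`COc1cc(-c2nnsc2-c2ccc(F)cc2)cc(OC)c1OC`) has no place on this scale: its entry is "not determined" (no result reported) and no result exists for it. Compound 4 (`COc1ccc(-c2snnc2-c2cc(OC)c(OC)c(OC)c2)cc1`) has not been measured yet.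

The structural change methoxy in place of fluoro on an aromatic carbon puts methoxy in place of fluoro on an aromatic carbon, para to a large group, so 4-fluorophenyl becomes 4-methoxyphenyl. With no number for compound 3, this step has no measured starting point, and no size can be read directly from the data. What can be stated is an expected landing place in this assay for the new compound: on the strong side of the scale, probably somewhat weaker than compound 1 at 1.5 nM but still a true number rather than a limit. Among the measured compounds shown here, this is a judgement resting on the single number available. Compound 4 is estimated at 25 nM in this test, with an expected range from 4 nM to 200 nM as its span.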

Compound 4, half-maximal inhibitory concentration: 14.5 nM
For compound 4 the middle estimate is 1.7-fold (0.24 log units) above the measured one, within the range that was stated.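

Compound 4 gives this position its first real number, showing that a methoxy on an aromatic carbon, para to a large group, can sit on the strong side of this assay, whereas a nitro in that place gives an at least 68-fold lower number from compound 2 to compound 4 (1.83 log units; beyond the scatter), a step well beyond the scatter. As far as these compounds go, the true size of that step is unknown, since the value of compound 2 is a limit of the assay and not a number: the limit of > 1000 nM in this assay, at which 1 of the 4 values shown sits. The comparison with compound 1 isolates a second place on the same core: hydrogen in place of hydroxy on an aromatic carbon gives a 9.7-fold higher number from compound 1 to compound 4 (0.99 log units; beyond the scatter), also beyond the scatter, so the hydroxy of compound 1 goes with the stronger result here, although compound 4 remains potent without it.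

From the compounds shown here alone, the step from the fluoro of compound 3 to the methoxy of compound 4 cannot be read, so the place of fluoro relative to methoxy remains unknown. Going by these compounds, how an amine, a carboxylic acid or a longer chain such as ethoxy would read in this same place also stays open.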